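A few compounds are considered here, and "the series" means these few. Any claim that something is new, unique, unknown or untested is made for them only; others in the source may bear on it.

Compound 1 `O=C(Nc1cccc(-c2ccc(-c3ccccc3)cc2)c1)C(Cl)Cl` is one of three compounds tested in a functional assay on KB 3-1 cells (Homo sapiens) for cytotoxicity, read by MTT assay, with a stated time of 68 h; on this read-out higher numbers stand for weaker inhibition and lower numbers for stronger inhibition. In this assay compound 1 gives > 50000 nM, which is a limit of the assay and not a number. Compound 1 therefore stands at the limit of > 50000 nM in this assay, at which 1 of the 3 values shown sits. Compound 2 `CC(C)Oc1ccc(-c2cc(NC(=O)C(Cl)Cl)cc(-c3ccc(OC(C)C)cc3)c2)cc1` and compound 3 `COc1cc(F)cc(-c2cc(NC(=O)C(Cl)Cl)cc(-c3cc(F)cc(OC)c3)c2)c1` carry further substituted aryl groups on the shared core; in this assay compound 2 gives 8850 nM and compound 3 gives 5990 nM. Going by the values given here, no step joins either of them to compound 1, so their values show only that some members give a measurable number.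

Compound 4 `O=C(Nc1cccc(-c2ccccc2)c1)C(Cl)Cl` differs from compound 1 by hydrogen in place of phenyl on an aromatic carbon. Among the compounds with values here, no measured step bears on this change, and compound 1 itself sits at the limit. The estimated step of a number no higher from compound 1 to compound 4 (the limit leaves the size open) is expected to be none beyond the scatter, leaving compound 4 at the limit as well. Compound 4 is accordingly estimated at 50000 nM, within a range from 20000 nM to 200000 nM, and the assay is expected most likely to report only a limit for it.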

Compound 4, half-maximal inhibitory concentration: 46800 nM
For compound 4 the middle estimate is 1.1-fold (0.03 log units) above the measured one; the measured number falls inside the stated range.
By their numbers in this assay, from the lowest: compounds 3 and 2 (each within the scatter of the next); then compound 4. At a limit, above all of these: compound 1.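

At this aromatic carbon, para to a large group, hydrogen in place of phenyl gives an at least 1.0-fold lower number from compound 1 to compound 4 (0.02 log units; that floor lies within the scatter), and compound 4 gives 46800 nM in this assay. In this assay compound 1 gives > 50000 nM, which is a limit of the assay and not a number. Losing the phenyl thus yields a number in place of a limit, but the step has only a floor, that floor lies within the scatter, and the real size of the step cannot be read: the limit of > 50000 nM in this assay, at which 1 of the 4 values shown sits.

The compounds shown leave open what a group other than hydrogen or phenyl, such as an amine or a carboxylic acid, would give on this aromatic carbon. Going by these compounds alone, no step joins compound 2 or compound 3 to compound 4 either, and how their aryl groups relate to this change remains open.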